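A Ring Replaces an Open Chain on Compound 2

The compounds below may be only part of what the source reports. "The series", "measured", "known", "first", "only" and "open" are said of these compounds alone.

Compound 1 `Cc1c(C(=O)OCCCN(C)C)oc2ccc(N(Cc3ccc(Br)cc3)S(=O)(=O)c3ccc(Br)cc3)cc12` and compound 2 `Cc1c(C(=O)NCC(O)CO)oc2ccc(N(Cc3ccc(Br)cc3)S(=O)(=O)c3ccc(Br)cc3)cc12` share one core and differ only in the group on a carbonyl carbon. In a functional assay on BXPC-3 cells (Homo sapiens) for antiproliferative activity, read by MTT assay, with a stated time of 48 h (on this read-out higher numbers stand for weaker inhibition and lower numbers for stronger inhibition), compound 1 gives 24200 nM and compound 2 gives 27600 nM. Going by the values given here, these two numbers cannot be told apart, so compound 2 stands level with compound 1, the only other measured compound. The next compound, compound 3 `Cc1c(C(=O)N2CCCC(C)C2)oc2ccc(N(Cc3ccc(Br)cc3)S(=O)(=O)c3ccc(Br)cc3)cc12`, carries 3-methylpiperidin-1-yl in place of (2,3-dihydroxypropyl)amino on that carbonyl carbon: 3-methylpiperidin-1-yl in place of (2,3-dihydroxypropyl)amino on a carbonyl carbon. Among the compounds with values here, only one measured step bears on this change, since it alters the same place: a 1.1-fold higher number from compound 1 to compound 2 (0.06 log units; within the scatter). That step is small, but it is a single guide, and neither measured compound has a ring in this place. On this thin evidence, no change beyond the scatter is expected in this assay. The expected step is a 1.3-fold lower number from compound 2 to compound 3 (0.10 log units; within the scatter). The estimated value for compound 3 is 22000 nM, with an expected range from 9000 nM to 50000 nM.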

Compound 3, half-maximal inhibitory concentration: 16700 nM
The estimate for compound 3 lay 1.3-fold (0.12 log units) above the measured number, and the stated range covers the measured number.
By their numbers in this assay, from the lowest: compounds 3, 1 and 2 (each within the scatter of the next).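

In this assay, going by these compounds alone, putting a ring on this carbonyl carbon for the first time gives a 1.7-fold lower number from compound 2 to compound 3 (0.22 log units; within the scatter) and, against the other open chain, a 1.4-fold lower number from compound 1 to compound 3 (0.16 log units; within the scatter). Neither step separates the compounds, so this place accepts 3-methylpiperidin-1-yl, with one six-membered non-aromatic ring and 0 hydrogen-bond donors, and the numbers stay level with those of compound 1 and compound 2, even though the (2,3-dihydroxypropyl)amino group it replaces carries 3 hydrogen-bond donors. Thus neither the ring nor the loss of those donors shows up as a real change in this cell read-out, although nothing measured alongside these numbers offers an explanation for that.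

Going by these compounds, all three compounds stand level, so it remains open whether any group on this carbonyl carbon can move the number beyond the usual scatter, as a carboxylic acid, a morpholine ring or a longer chain might or might not. On these data alone, it is also open whether the methyl of 3-methylpiperidin-1-yl plays any part, a question that a comparison with plain piperidin-1-yl would address.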